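Carboxycyclobutyl for carboxy-methylethyl: clearance outlook

The compounds below may be only part of what the source reports. "The series", "measured", "known", "first", "only" and "open" are said of these compounds alone.

Compound 1 is `CC(C)(NC(=O)Nc1ccc(F)c(C(F)(F)F)c1)C(=O)O` and compound 2 is `CC(C)(NC(=O)Nc1ccccc1)C(=O)O`; both share the same core. In an ADME assay on microsomes from liver (Mus musculus) for metabolic stability, using NADPH, with a stated time of 60 min (on this read-out lower numbers stand for slow clearance and higher numbers for fast clearance), compound 1 gives < 7 uL/min, which is a limit of the assay rather than a number. In this assay compound 2 likewise gives < 7 uL/min, again a limit. The two measured compounds thus both sit at the limit of < 7 uL/min in this assay, at which 2 of the 2 values shown sit, and no ordering between them can be drawn from these values. Compound 3 is `O=C(Nc1ccc(F)c(C(F)(F)F)c1)NC1(C(=O)O)CCC1` and has not yet been measured. Its difference from compound 1 is 1-carboxycyclobutyl in place of 1-carboxy-1-methylethyl on an amide-type nitrogen. Among the compounds with values here, no measured pair spans this change, so the expectation rests only on the two values at the limit. For compound 3 the step that the limit leaves unreadable from compound 1 to compound 3 is expected to be small, toward faster clearance if anything, and within the scatter. Compound 3 is estimated at 6 uL/min, with a range of 3 uL/min to 15 uL/min, and a fair chance that only a limit is again reported.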

Compound 3, intrinsic clearance in a liver preparation (reported as CLH), per the amount of preparation that the assay uses: < 7 uL/min
Compound 3: only a limit was reported; the forecaster's own chance of this, stated with the estimate: 60%; the middle value is on the limit's open side.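

In this assay compound 3 gives < 7 uL/min as a limit of the assay. No step between compound 1 and compound 3 can be read from these results, as all three compounds sit together: the limit of < 7 uL/min in this assay, at which 3 of the 3 values shown sit.
Whether 1-carboxycyclobutyl in place of 1-carboxy-1-methylethyl alters clearance at all remains open, as no compound shown gives a number on this read-out.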